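Amide variation on two related cores: antiproliferative notes

The compounds below may be only part of what the source reports. "The series", "measured", "known", "first", "only" and "open" are said of these compounds alone.

Measured compounds:
compound 1 `Cn1cc(-c2cnc3ccc(NC(=O)C4CC4)nc3c2)cn1`: > 50000 nM
compound 2 `Cn1cc(-c2cnc3ccc(NC(=O)c4ccc(F)cc4)nc3c2)cn1`: > 50000 nM
compound 3 `Cn1cc(-c2cnc3ccnc(NC(=O)C4CC4)c3c2)cn1`: > 50000 nM

In a functional assay on HeLa cells (Homo sapiens) for antiproliferative activity, read by MTT assay, with a stated time of 48 h (on this read-out higher numbers stand for weaker inhibition and lower numbers for stronger inhibition), compound 1 gives > 50000 nM, which is a limit of the assay and not a number. In this assay compound 2 likewise gives > 50000 nM, again a limit. Compound 3 gives > 50000 nM in this assay, also a limit.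

From compound 1 to compound 2 the change is 4-fluorophenyl in place of cyclopropyl on a carbonyl carbon. The step it made is a step that the two limits leave unreadable from compound 1 to compound 2, and it cannot be read because of the limit of > 50000 nM in this assay, at which 3 of the 3 values shown sit. Compound 3 has the same atoms as compound 1 joined differently; the difference between the two cores is not broken down here.

Compound 4 `Cn1cc(-c2cnc3ccnc(NC(=O)c4ccc(F)cc4)c3c2)cn1` is not yet measured. It stands to compound 3 as compound 2 stands to compound 1: the change is 4-fluorophenyl in place of cyclopropyl on a carbonyl carbon, at the same place as before, so this is the same change. On the core of compound 3 the expected step is a step that the limit leaves unreadable from compound 3 to compound 4, resting on a step that the two limits leave unreadable from compound 1 to compound 2 and on the fact that the two measured compounds of that core both sit at the limit of > 50000 nM in this assay, at which 3 of the 3 values shown sit. In this assay compound 4 is expected to give about 80000 nM. The expected range for compound 4 runs from 40000 nM to 200000 nM, and a limit rather than a number is the most probable outcome.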

Compound 4, half-maximal inhibitory concentration: > 50000 nM
Compound 4 ended at the assay's limit; the forecaster's own chance of this, stated with the estimate: 85%; the middle value does not contradict the limit.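

The step from compound 3 to compound 4, 4-fluorophenyl in place of cyclopropyl on a carbonyl carbon, cannot be read, because both compounds give a limit of the assay and not a number: the limit of > 50000 nM in this assay, at which 4 of the 4 values shown sit.

The compounds shown leave open how the cyclopropyl and 4-fluorophenyl amides rank on either core, and whether any amide on these two cores reaches a readable value in this assay.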